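Notes on a saturated-ring substituent swap

The source may report more compounds than this note shows. Statements on the series, on what has been measured and on what is new or still open speak of the compounds shown alone.

compound 1 `Cc1ccccc1N/C(=N\C#N)N1CCN(C(=O)Nc2ccc(Cl)cc2)C(c2ccccc2)C1`: 132 nM
compound 2 `Cc1ccccc1NC(=O)N1CCN(C(=O)Nc2ccc(Cl)cc2)C(c2ccccc2)C1`: 780 nM

In a functional assay for antagonist activity at P2X purinoceptor 7 (Homo sapiens), read by FLIPR and calcium flux (on this read-out lower numbers stand for stronger inhibition and higher numbers for weaker inhibition), compound 1 gives 132 nM, the lowest of the two numbers; compound 2 gives 780 nM, a higher number beyond the scatter. Compound 3 `Cc1ccccc1N/C(=N\C#N)N1CCN(C(=O)Nc2ccc(Cl)cc2)C(C(C)C)C1` differs from compound 1 by isopropyl in place of phenyl on a saturated ring carbon. Within the data shown here, no measured pair shows this change, so there is nothing here to calibrate it against. A moderate rise in the number, beyond the scatter, is expected: a 3.0-fold higher number from compound 1 to compound 3 (0.48 log units; beyond the scatter). Compound 3 is estimated at 400 nM in this assay, with a range from 120 nM to 1300 nM.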

Compound 3, half-maximal inhibitory concentration: 112 nM
Estimate against measurement, compound 3: 3.6-fold (0.55 log units) above; measured number below the stated range.
By their numbers in this assay, from the lowest: compounds 3 and 1 (each within the scatter of the next); then compound 2.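

In this assay, isopropyl in place of phenyl on a saturated ring carbon gives a 1.2-fold lower number from compound 1 to compound 3 (0.07 log units; within the scatter), so on the core of compound 1 this position does not need an aromatic ring to keep the number within the scatter. This single pair also shows that a group with no ring and fewer heavy atoms can stand here without a step beyond the scatter. No data at hand explain why the two groups read alike.

Still open, from the compounds shown here alone, is how a methyl, a cyclohexyl or an amine would read on this ring carbon. Also open, going by these compounds, is whether isopropyl in place of phenyl would give a similar step on compound 2.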